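This account rests on a few compounds, and the source may have more. Where it says the series, first, only, none or still open, it means among the compounds named here.

Three compounds here share one core and were tested in an in vitro functional assay on HEK293-A cells for positive allosteric modulation of metabotropic glutamate receptor 5 (Homo sapiens), read by FLIPR and calcium flux; on this read-out lower numbers stand for an effect already at smaller amounts and higher numbers for an effect only at larger amounts of compound. Compound 1 `O=C1CC(c2nc(-c3cccc(F)c3)no2)CN1c1ccc(Cl)cc1` gives 630 nM. Compound 2 `Cc1cccc(-c2noc(C3CC(=O)N(c4ccc(Cl)c(Cl)c4)C3)n2)c1` gives 390 nM. Compound 3 `O=C1CC(c2nc(-c3cccc(F)c3)no2)CN1c1ccc(F)cc1` gives 88 nM, the lowest of the three numbers, and its distance to both others lies beyond the scatter. For the measured compounds named here, only one pair differs in a single place: a 7.2-fold lower number from compound 1 to compound 3 (0.85 log units; beyond the scatter), where fluoro stands in place of chloro on the aromatic ring attached to the amide-type nitrogen in the ring.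

Compound 4 `O=C1CC(c2nc(-c3cccc(F)c3)no2)CN1c1ccc(Cl)c(Cl)c1` differs from compound 3 by 3,4-dichlorophenyl in place of 4-fluorophenyl on an amide-type nitrogen in a ring. Going by the values given here, this change runs against the one measured step, since it puts chloro back where compound 3 carries fluoro and adds a second chloro. Among the compounds with values here, compound 2 already carries 3,4-dichlorophenyl at the same place, and its value sits between those of compound 1 and compound 3, though it also differs from both on the other ring, so no clean step can be drawn from it. The step from compound 1 to compound 3 suggests that going back toward chloro should raise the number, and the expectation for compound 4 is therefore a modest rise, a 4.0-fold higher number from compound 3 to compound 4 (0.60 log units; beyond the scatter). Compound 4 is estimated at 350 nM, with a likely range from 120 nM to 1000 nM.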

Compound 4, half-maximal effective concentration: 3200 nM
For compound 4 the middle estimate is 9.1-fold (0.96 log units) below the measured one; measured number above the stated range.
By their numbers in this assay, from the lowest: compound 3; then compounds 2 and 1 (each within the scatter of the next); then compound 4.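

On the aromatic ring attached to the amide-type nitrogen, a further chloro proves costly: chloro in place of hydrogen gives a 5.1-fold higher number from compound 1 to compound 4 (0.71 log units; beyond the scatter), so adding to this ring, not only swapping fluoro for chloro, can raise the number. The full change from 4-fluorophenyl to 3,4-dichlorophenyl gives a 36-fold higher number from compound 3 to compound 4 (1.56 log units; beyond the scatter), the largest step among these compounds, which shows how strongly the read-out responds to the group at this position. The result for 3,4-dichlorophenyl also depends on the rest of the molecule, as fluoro in place of methyl on the other aromatic ring gives an 8.2-fold higher number from compound 2 to compound 4 (0.91 log units; beyond the scatter), a change that leaves 3,4-dichlorophenyl in place. Nothing available here explains why these changes have these effects.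

On the amide-type nitrogen, the compounds shown carry only phenyl rings bearing fluoro or chloro, so the outcome with 3,4-difluorophenyl, or with a phenyl ring bearing a methoxy group or a nitrile, remains open. Going by these compounds, it is also open whether methyl in place of fluoro on the other aromatic ring would lower the number when 4-fluorophenyl sits on the nitrogen, as it does in compound 3.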